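The source may hold more compounds than are shown below. What is called first, only, known or untested is meant among the compounds shown, and "the series" means these compounds.

Compound 2, `COc1cccc(Cc2nc3c(-c4ccc(Cl)cc4)n[nH]c3c(=O)n2NC(=O)c2ccccc2)c1`, is one of two compounds with a number in a functional assay on HT-29 cells (Homo sapiens) for inhibition, read by MTT assay, with a stated time of 2 days (a lower number here means a stronger inhibitor of growth, a higher number a weaker inhibitor of growth), where compound 2 gives 22100 nM. Compound 1, `O=C(Nn1c(-c2cccc([N+](=O)[O-])c2)nc2c(-c3ccc(Cl)cc3)n[nH]c2c1=O)c1ccccc1`, differs from it in a single place, and in this assay compound 1 gives 18500 nM. The step of a 1.2-fold higher number from compound 1 to compound 2 (0.08 log units; within the scatter) shows that swapping one side group for another at that spot left the number where it was. Compound 2 thus has the higher of the two numbers, but only by a margin within the scatter, so no order between them can be read.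

Compound 3, `O=C(Nn1c(CCc2ccccc2)nc2c(-c3ccc(Cl)cc3)n[nH]c2c1=O)c1ccccc1`, changes the same side group again: benzyl in place of 3-methoxyphenyl on a saturated chain carbon bound to an aromatic carbon. Going by the values given here, the only step that bears on this position is the one from compound 1 to compound 2, and it stayed within the scatter, so the expected step of a 1.1-fold lower number from compound 2 to compound 3 (0.04 log units; within the scatter) is also none beyond the scatter. Compound 3 is therefore estimated at 20000 nM in this assay, with a range from 8000 nM to 50000 nM.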

Compound 3, concentration for 50% growth inhibition: 23400 nM
For compound 3 the middle estimate is 1.2-fold (0.07 log units) below the measured one; low and high end bracket the measured number.
By their numbers in this assay, from the lowest: compounds 1, 2 and 3 (each within the scatter of the next).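

Going from 3-methoxybenzyl to phenethyl gives a 1.1-fold higher number from compound 2 to compound 3 (0.02 log units; within the scatter) and going from 3-nitrophenyl to phenethyl gives a 1.3-fold higher number from compound 1 to compound 3 (0.10 log units; within the scatter) in this assay. The methoxy oxygen, the single hydrogen-bond acceptor in the group that leaves, can therefore be absent with no shift beyond the scatter. Across these three compounds, a side group with a nitro substituent, one with a methoxy substituent and one with neither cannot be told apart, and nothing in the available data explains this.

As far as these compounds go, each of these side groups still carries a six-membered aromatic ring of carbon only, so it remains open whether an amine, a carboxylic acid or a longer chain at this spot would move the number beyond the scatter. From the compounds shown here alone, whether changes elsewhere on the shared core matter more also remains open.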